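This account rests on a few compounds, and the source may have more. Where it says the series, first, only, none or still open, it means among the compounds named here.

Measured so far:
compound 1 `N#Cc1cccc(C(=O)Nc2cc(-c3ccccc3)nn2-c2ccccc2Br)c1` — in a functional assay on cells for positive allosteric modulation of metabotropic glutamate receptor 5 (Rattus norvegicus), read by calcium flux (on this read-out higher numbers stand for an effect only at larger amounts of compound and lower numbers for an effect already at smaller amounts), compound 1 gives 50 nM
compound 2 `N#Cc1cccc(C(=O)Nc2cn(-c3ccccc3)nc2-c2ccccc2)c1` — in this assay compound 2 gives only the limit > 10000 nM

Compound 2 stands at the limit of this assay, with no number to place it; this is the point marked by the limit of > 10000 nM in this assay, at which 1 of the 2 values shown sits. Among the compounds with values here, compound 1 and compound 2 share the amide aryl and differ in their cores, and no single-point step connects the two, so their values are only set side by side. Compound 3 `O=C(Nc1cn(-c2ccccc2)nc1-c1ccccc1)c1ccc([N+](=O)[O-])cc1` keeps the core of compound 2 and changes the amide aryl: 4-nitrophenyl in place of 3-cyanophenyl on a carbonyl carbon. Within the data shown here, no step of this kind is measured in the set, and the starting point is a limit rather than a number. The step that the limit leaves unreadable from compound 2 to compound 3 is expected to be none beyond the scatter, with the value staying near the limit. Compound 3 is expected at 15000 nM in this assay, in the range 3000 nM to 60000 nM, and a further limit-only reading is quite possible.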

Compound 3, half-maximal effective concentration: > 10000 nM
Compound 3 ended at the assay's limit (the forecaster's own chance of this, stated with the estimate: 70%); the middle value does not contradict the limit.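

In this assay compound 2 and compound 3 both give only a limit, so no step can be read between them: the limit of > 10000 nM in this assay, at which 2 of the 3 values shown sit. Going by these compounds, whether any amide aryl on the core of compound 2 gives a readable value, and what a single change separating that core from the core of compound 1 would do, stays open.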